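From Ethyl to Hydroxymethyl on a Shared Core

The source may report more compounds than this note shows. Statements on the series, on what has been measured and on what is new or still open speak of the compounds shown alone.

Of the compounds shown here, three built on one shared core have been tested in a functional assay on the whole organism with Rattus norvegicus as the target, read by paw edema, with a stated time of 3 h, at a dose of 100 mg/kg by the oral route; a lower number here means less inhibition, a higher number more inhibition at the dose given (going by the name of the read-out). Compound 1 `Cc1cccnc1-c1nc2ccccc2[nH]1` gives 17%, compound 2 `Cc1ccnc(-c2nc3ccccc3[nH]2)c1` gives -4%, and compound 3 `CCc1ccc(-c2nc3ccccc3[nH]2)nc1` gives 44%. Compound 3 thus holds the highest of the three numbers, standing beyond the scatter above compound 1 and further still above compound 2. Compound 4 `OCc1ccc(-c2nc3ccccc3[nH]2)nc1` has not yet been measured. It differs from compound 3 in a single place: hydroxy in place of methyl on a saturated chain carbon bound to an aromatic carbon. Among the compounds with values here, no measured pair shows this particular change, so its effect is open. For compound 4 a step of a number 14 percentage points lower from compound 3 to compound 4 (beyond the scatter) is expected, a modest loss that may still fall within the scatter. Compound 4 is therefore estimated at 30%, with a range from 5% to 55%.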

Compound 4, a percentage reported as inhibition, in the whole organism at one dose (the size of the read-out at that dose, not a potency): -10%
Estimate against measurement, compound 4: 40 percentage points above, and the stated range ends above it.
By their numbers in this assay, from the lowest: compounds 4 and 2 (each within the scatter of the next); then compound 1; then compound 3.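

In this assay the change from ethyl to hydroxymethyl gives a number 54 percentage points lower from compound 3 to compound 4 (beyond the scatter) at this place, on a saturated chain carbon bound to an aromatic carbon. The earlier compounds shown here did not show this: here, exchanging one carbon for one oxygen is enough to lose all of the inhibition seen with ethyl. Nothing measured here accounts for the drop.

On these data alone, whether the loss is specific to hydroxy remains open. Methoxymethyl, aminomethyl or a longer chain such as propyl at this place would help to settle that.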